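This account rests on a few compounds, and the source may have more. Where it says the series, first, only, none or still open, it means among the compounds named here.

Measured compounds:
- Compound 1 `C=Cc1cn2ncc(-c3ccnc(OC)c3)c2nc1NC`: 190 nM
- Compound 2 `COc1cc(-c2cnn3cc(OC)c(-c4cc(C)no4)nc23)ccn1`: 3000 nM
- Compound 3 `COc1cn2ncc(-c3ccnc(OC(C)(C)C)c3)c2nc1-c1cnn(C)c1`: 800 nM

In an assay on isolated protein for inhibition of activin receptor type-2A (Homo sapiens), read by 33P incorporation, with a stated time of 20 min, in the presence of a further agent that is not named here (a higher number here means a weaker inhibitor, a lower number a stronger inhibitor), compound 2 stands at the highest number of the three. Its nearest neighbour is compound 3, whose number is lower by a gap beyond the scatter, and the furthest is compound 1, lower by a larger gap, also beyond the scatter. Compound 2 is thus the weakest inhibitor of the three measured.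

Compound 4 `COc1cc(-c2cnn3cc(OC)c(N(C)C)nc23)ccn1` has not yet been measured in this assay. Compared with compound 2 the change is: dimethylamino in place of 3-methyl-1,2-oxazol-5-yl on an aromatic carbon. Going by the values given here, no measured pair shows this exact exchange, so the expectation rests on the three values above. A smaller amino substituent on the shared core is seen in compound 1, which gives 190 nM, and the five-membered heteroaryl substituents in compound 2 and compound 3 sit at higher numbers. On that basis the step to compound 4 is expected to go toward a lower number, of moderate size, though the change is larger than any measured step and the range is kept wide. Compound 4 is expected to give about 600 nM, within 150 nM to 2500 nM. The expected step is a 5.0-fold lower number from compound 2 to compound 4 (0.70 log units; beyond the scatter).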

Compound 4, half-maximal inhibitory concentration: 3000 nM
The estimate for compound 4 lay 5.0-fold (0.70 log units) below the measured number; the whole stated range lies below it.
By their numbers in this assay, from the lowest: compound 1; then compound 3; then compounds 2 and 4 (each within the scatter of the next).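

In this assay, dimethylamino in place of 3-methyl-1,2-oxazol-5-yl, on the aromatic carbon next to the ring nitrogen and ortho to a methoxy group, gives no change at the digits printed from compound 2 to compound 4 (within the scatter) as its step. With the rest of the structure held constant, this first single-place comparison does not separate a five-membered aromatic ring from an open group without a ring at this position, so neither group is set apart by the number. No supporting data bear on why the two groups read alike.

Still open, on these data alone, is whether this position stays equally flat with a morpholine, a primary amine or a carboxylic acid on the same aromatic carbon. Also open, as far as these compounds go, is whether the same exchange reads alike when an ethoxy group replaces the methoxy group.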